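Swapping the aryl on the triazole of a weak series

The source may hold more compounds than are shown below. What is called first, only, known or untested is meant among the compounds shown, and "the series" means these compounds.

All three measured compounds share one core and differ only in the aryl group on the triazole nitrogen. In a functional assay on PC-3 cells (Homo sapiens) for inhibition, read by MTT assay, with a stated time of 72 h (on this read-out higher numbers stand for weaker inhibition and lower numbers for stronger inhibition), compound 1 `CC(C)n1ncc2c(C(=O)NCc3cn(-c4ccc(F)cc4)nn3)cccc21` gives > 40000 nM, which is a limit of the assay and not a number. Compound 3 `CC(C)n1ncc2c(C(=O)NCc3cn(-c4ccccc4F)nn3)cccc21` likewise sits at the limit > 40000 nM in this assay. Compound 2 `Cc1cccc(-n2cc(CNC(=O)c3cccc4c3cnn4C(C)C)nn2)c1` gives 32300 nM in this assay. Two of the three values therefore rest at the same limit, as the limit of > 40000 nM in this assay, at which 2 of the 3 values shown sit, records, so compound 3 stands among the weakest numbers shown without any readable distance to compound 1. The step of an at least 1.2-fold lower number from compound 1 to compound 2 (0.09 log units; that floor lies within the scatter) and the step of an at least 1.2-fold higher number from compound 2 to compound 3 (0.09 log units; that floor lies within the scatter) are both floors that lie within the scatter, and the step that the two limits leave unreadable from compound 1 to compound 3 cannot be read at all.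

Compound 4 `CCc1ccc(-n2cc(CNC(=O)c3cccc4c3cnn4C(C)C)nn2)cc1` carries the change (4-ethylphenyl in place of 2-fluorophenyl on an aromatic nitrogen). For the measured compounds named here, no measured step bears directly on an ethyl group, and the steps that do exist between aryl variants are all small or unreadable, so the account expects a step of a number no higher from compound 3 to compound 4 (the limit leaves the size open) that does not rise beyond the scatter. Compound 4 is accordingly estimated at 40000 nM in this assay, within a range from 15000 nM to 100000 nM, with a fair chance that only a limit is reported.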

Compound 4, half-maximal inhibitory concentration: 26600 nM
Compound 4: the middle estimate sits 1.5-fold (0.18 log units) above what was measured; low and high end bracket the measured number.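

For the compounds shown here, with compound 4, this position gains a second aryl group that gives a number rather than a limit, and the first step between two real numbers shows nothing beyond the scatter: a 1.2-fold lower number from compound 2 to compound 4 (0.08 log units; within the scatter). The 3-methylphenyl and 4-ethylphenyl groups both read as numbers while the two fluorophenyl groups sit at a limit, and no compound shown goes against that split, yet it remains a division of four compounds and not a demonstrated difference, as the two remaining steps, an at least 1.5-fold lower number from compound 3 to compound 4 (0.17 log units; that floor lies within the scatter) and an at least 1.5-fold lower number from compound 1 to compound 4 (0.17 log units; that floor lies within the scatter), are floors within the scatter. Those floors cannot be sharpened because their starting values are limits and not numbers: the limit of > 40000 nM in this assay, at which 2 of the 4 values shown sit.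

The compounds shown leave open whether any group on this aryl ring can move the number in this assay beyond the scatter, in either direction. Going by these compounds, an amine or a carboxylic acid on the phenyl ring, or a chain longer than ethyl, lies outside this set, so how such groups would read at this position remains unknown.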